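The source may hold more compounds than are shown below. What is called first, only, known or untested is meant among the compounds shown, and "the series" means these compounds.

Values so far in an ADME assay on microsomes from liver (Mus musculus) for metabolic stability, read by HPLC, with a stated time of 4 h (a lower number here means that the compound disappears faster, a higher number that the compound lasts longer), are:
- compound 1 `CN(C)c1ccc2cc(-c3ccccn3)c(N)nc2c1` gives < 0.1 h (a limit of the assay, not a number)
- compound 2 `CN(C)c1ccc2cc(-c3cn(C)c4ccccc34)c(N)nc2c1` gives 0.26 h (the only actual number)

Within the data shown here, compound 2 is therefore the only point that can serve as a numerical reference in this assay so far. The result for compound 1 is a limit and gives no number to compare.

Compound 3 `Cn1cc(-c2cc3ccc(N4CCCCC4)cc3nc2N)c2ccccc21` keeps the rest of compound 2 and carries piperidin-1-yl in place of dimethylamino on an aromatic carbon of a six-membered aromatic ring of carbon only. No measured pair in the series isolates this exchange, so its size and direction are not shown by the data. The expectation is anchored on compound 2 at 0.26 h and allows for no step beyond the usual scatter, with a slightly shorter half-life a little more likely than a longer one. The expected change is a 1.3-fold lower number from compound 2 to compound 3 (0.11 log units; within the scatter) and would remain small. For compound 3 the estimated half-life is 0.2 h, with an expected range from 0.1 h to 0.4 h and some chance of a limit instead of a number.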

Compound 3, half-life: 0.8 h
Compound 3: the middle estimate sits 4.0-fold (0.60 log units) below what was measured, and the stated range ends below it.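

In this assay, dimethylamino replaced by piperidin-1-yl on the aromatic carbon gives a 3.1-fold higher number from compound 2 to compound 3 (0.49 log units; beyond the scatter). Among these compounds, this is the first pair that differs in one place, and it shows that the half-life responds to the group at this position while the rest of compound 2 stays unchanged. The reading rests on this single pair, and compound 3 at 0.8 h remains near the short end of the read-out. Compound 1 already touches the floor of the assay, which is a limit and not a number: the limit of < 0.1 h in this assay, at which 1 of the 3 values shown sits.

From the compounds shown here alone, whether the step belongs to the closed ring of piperidin-1-yl or simply to a larger group on this carbon stays open, and an open chain such as diethylamino, or a ring with a second hetero atom such as morpholin-4-yl, would help to separate the two. Among the compounds shown here, whether the same exchange would lengthen the half-life on the core of compound 1, which carries a different ring in place of the one shared by compound 2 and compound 3, also stays open.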